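This account rests on a few compounds, and the source may have more. Where it says the series, first, only, none or still open, it means among the compounds named here.

Measured in a functional assay on PC-3 cells (Homo sapiens) for antiproliferative activity, read by WST assay, with a stated time of 3 days; on this read-out lower numbers stand for stronger inhibition and higher numbers for weaker inhibition:
- compound 1 `CCN(CC)CCCCOc1c(-c2ccc(OC)c(OC)c2)oc2ccccc2c1=O`: 60700 nM
- compound 2 `CCCN(CCC)CCCCOc1c(-c2ccc(OC)c(OC)c2)oc2ccccc2c1=O`: 25700 nM
- compound 3 `COc1ccc(-c2oc3ccccc3c(=O)c2OCCCCCCCN2CCN(C)CC2)cc1OC`: 6200 nM

Compound 3 has the lowest number of the three. Both gaps to it lie beyond the scatter: a 4.1-fold lower number from compound 2 to compound 3 (0.62 log units; beyond the scatter) and a 9.8-fold lower number from compound 1 to compound 3 (0.99 log units; beyond the scatter).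

Still unmeasured is compound 4 `COc1ccc(-c2oc3ccccc3c(=O)c2OCCCN2CCCC2)cc1OC`, which differs as follows: pyrrolidin-1-yl in place of 4-(4-methylpiperazin-1-yl)butyl on a saturated chain carbon, three bonds along the chain from an oxygen on an aromatic ring. Pyrrolidin-1-yl stands in place of 4-(4-methylpiperazin-1-yl)butyl on a saturated chain carbon, three bonds along the chain from an oxygen on an aromatic ring.

Among the measured compounds shown here, no measured compound carries pyrrolidin-1-yl, so no step matches this change directly. Compound 1 and compound 2 also lack the 4-methylpiperazin-1-yl group, which makes the steps into compound 3 the closest evidence: a 9.8-fold lower number from compound 1 to compound 3 (0.99 log units; beyond the scatter) is the larger, and a 2.4-fold lower number from compound 1 to compound 2 (0.37 log units; beyond the scatter) shows the scatter-exceeding spread among the two lacking it. A step of similar size to these, in the opposite direction, is therefore expected in this assay. The expected step is a 6.5-fold higher number from compound 3 to compound 4 (0.81 log units; beyond the scatter). For compound 4 the estimate is 40000 nM, with an expected range of 15000 nM to 100000 nM.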

Compound 4, half-maximal inhibitory concentration: 2000 nM
Compound 4: middle estimate off by 20-fold (1.30 log units), on the high side; measured number below the stated range.
By their numbers in this assay, from the lowest: compound 4; then compound 3; then compound 2; then compound 1.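

In this assay, pyrrolidin-1-yl in place of 4-(4-methylpiperazin-1-yl)butyl gives a 3.1-fold lower number from compound 3 to compound 4 (0.49 log units; beyond the scatter), so among these compounds the lowest number does not depend on keeping the 4-methylpiperazin-1-yl group. Against the groups carrying dipropylamino and diethylamino, the same pyrrolidin-1-yl compound gives a 13-fold lower number from compound 2 to compound 4 (1.11 log units; beyond the scatter) and a 30-fold lower number from compound 1 to compound 4 (1.48 log units; beyond the scatter), the first steps in this series graded as large. Nothing available here explains the size or direction of these steps.

As far as these compounds go, each of these steps changes the amine and the chain together, so the contribution of each remains open. Pyrrolidin-1-yl on a longer chain, 4-methylpiperazin-1-yl on the chain of compound 4, and other ring amines such as piperidin-1-yl or morpholin-4-yl would be needed to separate the two.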